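This account rests on a few compounds, and the source may have more. Where it says the series, first, only, none or still open, it means among the compounds named here.

Measured compounds:
Compound 1, `COc1ccc(-c2cc(NO)c(C(=O)Nc3ccc(C)cc3)c(=O)o2)cc1`: in an ADME assay on Huh-7 cells (Homo sapiens) for cytotoxicity, read by a luciferase reporter and WST assay, with a stated time of 3 days (on this read-out lower numbers stand for higher toxicity in this test and higher numbers for lower toxicity in this test), compound 1 gives > 20000 nM, a limit of the assay.
Compound 2, `COc1ccc(-c2cc(NO)c(C(=O)NCCO)c(=O)o2)cc1`: in this assay compound 2 gives > 20000 nM, again a limit.
Compound 3, `O=C(NCc1ccccc1)c1c(NO)cc(-c2ccc(Cl)cc2)oc1=O`: in this assay compound 3 gives > 20000 nM, also a limit.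

Only one pair among these differs in a single place. The step from compound 1 to compound 2 in this assay is a step that the two limits leave unreadable from compound 1 to compound 2, the change being 2-hydroxyethyl in place of 4-methylphenyl on an amide-type nitrogen; with both ends at a limit, its size cannot be read. Compound 3 thus stands where every measured value stands, at the limit of > 20000 nM in this assay, at which 3 of the 3 values shown sit.

Compound 4, `COc1ccc(-c2cc(NO)c(C(=O)NCc3ccccc3)c(=O)o2)cc1`, differs from compound 3 by methoxy in place of chloro on an aromatic carbon. Among the compounds with values here, no measured step touches that ring, and the single measured step, from compound 1 to compound 2, is unreadable, so nothing among the measurements points to a change in this assay in either direction. The step from compound 3 to compound 4 is therefore expected to be a step that the limit leaves unreadable from compound 3 to compound 4, nothing beyond the scatter. Compound 4 is accordingly estimated to sit at 30000 nM, within a range from 15000 nM to 80000 nM, most likely reported again only as a limit.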

Compound 4, half-maximal cytotoxic concentration: > 20000 nM
Compound 4 gave a limit, no number; the forecaster's own chance of this, stated with the estimate: 85%; the middle value lies beyond the limit too.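

In this assay compound 4 gives > 20000 nM, which is a limit. Within the data shown here, its steps from compound 1, compound 2 and compound 3 cannot be read, so no new step comes out of this result. The compounds shown leave open whether any change among them shifts the read-out in this assay, since all of them sit together: the limit of > 20000 nM in this assay, at which 4 of the 4 values shown sit.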